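The source may hold more compounds than are shown below. What is called first, only, known or untested is meant among the compounds shown, and "the series" means these compounds.

Measured compounds:
compound 1, `Brc1cn2ccnc2c(-c2ccc3ncn(C4CCCCC4)c3c2)n1`: 18.1%
compound 2, `c1ccc(-c2cn3ccnc3c(-c3ccc4ncn(C5CCCCC5)c4c3)n2)cc1`: 5.25%

In a functional assay on NCI-H322M cells (Homo sapiens) for inhibition, read by sulforhodamine B assay, with a stated time of 48 h, tested at 10 uM (a lower number here means less inhibition, a higher number more inhibition at the concentration tested (going by the name of the read-out)), compound 1 gives 18.1%, the higher of the two numbers recorded; its nearest neighbour, compound 2, gives 5.25%. For the measured compounds named here, the one measured step separating them, phenyl in place of bromo on an aromatic carbon, is a number 12.9 percentage points lower from compound 1 to compound 2 (beyond the scatter).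

Compound 3, `c1ccc2c(-c3cn4ccnc4c(-c4ccc5ncn(C6CCCCC6)c5c4)n3)cccc2c1`, differs from compound 1 in the same place: naphthalen-1-yl in place of bromo on an aromatic carbon. Going by the values given here, the only step that bears on this change is the phenyl step, which went a number 12.9 percentage points lower from compound 1 to compound 2 (beyond the scatter). Since naphthalen-1-yl, like phenyl, is an aromatic carbon group replacing bromo at the same position, a drop of similar size is expected, meaning a step of a number 11.1 percentage points lower from compound 1 to compound 3 (beyond the scatter). Compound 3 is therefore estimated to give 7% in this assay, with a plausible range from -3% to 18%.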

Compound 3, a percentage reported as inhibition, at one concentration (the size of the read-out at that concentration, not a potency): 4.74%
For compound 3 the middle estimate is 2.3 percentage points above the measured one, within the range that was stated.
By their numbers in this assay, from the lowest: compounds 3 and 2 (each within the scatter of the next); then compound 1.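

In this assay, naphthalen-1-yl in place of bromo gives a number 13.4 percentage points lower from compound 1 to compound 3 (beyond the scatter), so a second aromatic carbon group at this position also falls short of the bromo compound. Going from phenyl to naphthalen-1-yl, with its 2 six-membered aromatic rings of carbon only, gives a number 0.5 percentage points lower from compound 2 to compound 3 (within the scatter), so the extra ring makes no difference that can be told apart in this read-out. Nothing available here accounts for these numbers.

Still open, as far as these compounds go, is how a non-aromatic group at this position, such as an amine, a carboxylic acid or a longer alkyl chain, would compare with bromo and with these two aromatic groups. Also open, from the compounds shown here alone, is whether the same picture would hold at other concentrations or in other cell lines.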